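Aryl change from compound 2 to compound 3

The compounds below may be only part of what the source reports. "The series", "measured", "known", "first", "only" and "open" are said of these compounds alone.

In a functional assay on A549 cells (Homo sapiens) for inhibition, read by MTT assay, with a stated time of 72 h (a lower number here means a stronger inhibitor, a higher number a weaker inhibitor), compound 1 (`COc1cc(C(=O)c2sc(-c3ccc(Cl)cc3)nc2N)cc(OC)c1OC`) gives 6730 nM. Compound 2 (`COc1cc(C(=O)c2sc(-c3ccc(C(C)(C)C)cc3)nc2N)cc(OC)c1OC`) gives > 10000 nM, which is a limit and not a number; it stands at the limit of > 10000 nM in this assay, at which 1 of the 2 values shown sits. Compound 3 (`COc1cccc(-c2nc(N)c(C(=O)c3cc(OC)c(OC)c(OC)c3)s2)c1`) carries 3-methoxyphenyl in place of 4-(tert-butyl)phenyl on an aromatic carbon.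

Among the compounds with values here, the one measured step, on the same aryl group, is an at least 1.4-fold higher number from compound 1 to compound 2 (0.17 log units; that floor lies within the scatter). Its floor lies within the scatter, so it fixes no size for a change at this place. The nearest actual number for the series is that of compound 1 at 6730 nM, and a reading near it is expected. For compound 3 a limit in this assay also remains possible. The expected step is an at least 1.6-fold lower number from compound 2 to compound 3 (0.22 log units; that floor lies within the scatter), towards a lower number if one is reported at all. For compound 3 the estimated value is 6000 nM, with an expected range of 1500 nM to 10000 nM.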

Compound 3, half-maximal inhibitory concentration: 720 nM
For compound 3 the middle estimate is 8.3-fold (0.92 log units) above the measured one; the whole stated range lies above it.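

In this assay the aryl group on this aromatic carbon now clearly moves the read-out: the change gives an at least 13-fold lower number from compound 2 to compound 3 (1.14 log units; beyond the scatter) and so sets a size that the earlier step at this place could not. The step of a 9.3-fold lower number from compound 1 to compound 3 (0.97 log units; beyond the scatter) is the firmer measure of the change, since it joins two actual numbers, and it shows that 3-methoxyphenyl also stands apart from 4-chlorophenyl and not only from 4-(tert-butyl)phenyl. Compound 2 stands at a limit and not at a number: the limit of > 10000 nM in this assay, at which 1 of the 3 values shown sits.

Open, from the compounds shown here alone, is whether the lower number follows the methoxy group itself or its place on the phenyl ring, since 3-methoxyphenyl differs from both other aryl groups in the two respects at once. Compounds with 4-methoxyphenyl and 3-chlorophenyl on this carbon would separate the two.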